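Swapping the aryl group on the triazole nitrogen

The source may report more compounds than this note shows. Statements on the series, on what has been measured and on what is new or still open speak of the compounds shown alone.

Measured compounds:
compound 1 `CN(CCNCc1cn(-c2ccc(Cl)cc2)nn1)CCNc1ccnc2cc(Cl)ccc12` — 9500 nM
compound 2 `CN(CCNCc1cn(Cc2ccccc2)nn1)CCNc1ccnc2cc(Cl)ccc12` — 16000 nM
compound 3 `CN(CCNCc1cn(-c2nc3ccccc3[nH]2)nn1)CCNc1ccnc2cc(Cl)ccc12` — 32000 nM

In a functional assay on HCC827 cells (Homo sapiens) for antiproliferative activity, read by sulforhodamine B assay, with a stated time of 72 h (on this read-out higher numbers stand for weaker inhibition and lower numbers for stronger inhibition), compound 1 gives the lowest of the three numbers. Compound 2 and compound 3 differ from it only in the group on the aromatic nitrogen of the five-membered ring: the change a 1.7-fold higher number from compound 1 to compound 2 (0.23 log units; within the scatter) stays within the scatter, while the change a 3.4-fold higher number from compound 1 to compound 3 (0.53 log units; beyond the scatter) is a modest step beyond it. Between the other two, a 2.0-fold higher number from compound 2 to compound 3 (0.30 log units; within the scatter) stays within the scatter.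

Compound 4 `CN(CCNCc1cn(-c2ccnc3cc(Cl)ccc23)nn1)CCNc1ccnc2cc(Cl)ccc12` has not yet been measured in this assay. It differs from compound 1 by 7-chloroquinolin-4-yl in place of 4-chlorophenyl on an aromatic nitrogen. Among the compounds with values here, no measured step puts this group on the aromatic nitrogen, so the three steps bear on it only by showing that exchanges at this place moved the number little, and then upward. Compound 4 is therefore expected to land near compound 1, with a step of a 1.1-fold higher number from compound 1 to compound 4 (0.02 log units; within the scatter) that is expected to stay within the scatter. The estimate for compound 4 is 10000 nM, expected between 3500 nM and 30000 nM.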

Compound 4, half-maximal inhibitory concentration: 18000 nM
Compound 4: the middle estimate sits 1.8-fold (0.26 log units) below what was measured, and the stated range covers the measured number.
By their numbers in this assay, from the lowest: compounds 1, 2, 4 and 3 (each within the scatter of the next, the first and the last beyond it).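

In this assay, 7-chloroquinolin-4-yl, with its added ring and ring nitrogen, can stand on the aromatic nitrogen without any step leaving the scatter (a 1.9-fold higher number from compound 1 to compound 4 (0.28 log units; within the scatter); a 1.1-fold higher number from compound 2 to compound 4 (0.05 log units; within the scatter); a 1.8-fold lower number from compound 3 to compound 4 (0.25 log units; within the scatter)). Compound 4 therefore cannot be told apart from any of the other three, even though compound 1 and compound 3 lie beyond the scatter of each other. Nothing available explains these small differences.

All four groups carry an aromatic ring, so the compounds shown leave open whether an aminoethyl chain or a carboxylic acid on this nitrogen would move the number beyond the scatter of compound 1. They also leave open what a quinolin-4-yl group without the chlorine, or a morpholine-bearing chain, would do here.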